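Taking the butyl chain off compound 2

This account rests on a few compounds, and the source may have more. Where it says the series, first, only, none or still open, it means among the compounds named here.

For the measured compounds named here, in a physicochemical assay for lipophilicity (a lower number here means a more polar compound, a higher number a more lipophilic compound), compound 2 (`CCCC[C@H]1CN(c2cccc(C)c2C)C(=O)C(=O)N1Cc1cncn1Cc1ccc(C#N)cc1`) gives 3.3, the highest of the three numbers measured so far. The nearest value belongs to compound 3 (`N#Cc1ccc(Cn2cncc2CN2CCN(c3ccccc3)C(=O)C2)cc1`) at 1.32, and the furthest to compound 1 (`N#Cc1ccc(Cn2cncc2CN2CC(=O)N(c3ccccc3)CC2=O)cc1`) at 0.55. Both gaps lie beyond the scatter.

The next compound, compound 4 (`Cc1cccc(N2CCN(Cc3cncn3Cc3ccc(C#N)cc3)C(=O)C2=O)c1C`), is compound 2 with hydrogen in place of butyl on a saturated ring carbon. Going by the values given here, no measured pair of compounds differs by this change alone, so its size cannot be read directly. Among the compounds with values here, the only guide is indirect. Compound 3 at 1.32 and compound 1 at 0.55 carry no butyl chain and both sit well under compound 2, although they differ from it elsewhere too.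

A clear fall in this assay, beyond the scatter, is therefore expected, with an estimated a number 1.80 log units lower from compound 2 to compound 4 (beyond the scatter). For compound 4 the estimated value is 1.5, with an expected range of 1 to 2.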

Compound 4, partition coefficient: 1.11
Estimate against measurement, compound 4: 0.39 log units above; the measured number falls inside the stated range.
By their numbers in this assay, from the lowest: compound 1; then compounds 4 and 3 (each within the scatter of the next); then compound 2.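

For the compounds shown here, measured in this assay, swapping butyl for hydrogen on this saturated ring carbon gives a number 2.19 log units lower from compound 2 to compound 4 (beyond the scatter) as the first direct reading of this change. Earlier compounds differed from compound 2 in more than one place, whereas this pair differs only here, so the large step belongs to this single change. This shows that the position is not a silent one in this assay, although nothing available explains the size of the step.

One pair cannot show how the number moves along a series of groups on this ring carbon, such as a methyl, an ethyl, a longer chain like hexyl, or an amine or a carboxylic acid. Going by these compounds, it also remains open whether the same swap would give a similar step with a plain phenyl in place of the 2,3-dimethylphenyl group.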